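The source may hold more compounds than are shown below. What is called first, only, known or untested is meant among the compounds shown, and "the series" means these compounds.

Going by the values given here, compound 2 `Nc1cc(N)c2nc(-c3ccccc3)c(Oc3ccc(F)cc3)nc2c1` is the one member of this small set with a number in a functional assay on SF-539 cells (Homo sapiens) for inhibition, read by sulforhodamine B assay, with a stated time of 48 h (a higher number here means that more compound is tolerated, a lower number that less compound is tolerated), where compound 2 gives 70800 nM. Compound 1 `COc1ccc(Sc2nc3cc(N)cc(N)c3nc2-c2ccccc2)cc1` reaches in this assay only a limit, < 100000 nM. The step that the limit leaves unreadable from compound 1 to compound 2 therefore cannot be read, and the single record of this kind is the limit of < 100000 nM in this assay, at which 1 of the 2 values shown sits. Compound 3 `Nc1cc(N)c2nc(-c3ccccc3)c(Sc3ccc(F)cc3)nc2c1` is the next compound in the series, made from compound 2 by (4-fluorophenyl)sulfanyl in place of 4-fluorophenoxy on an aromatic carbon. Among the compounds with values here, no measured step with a readable size bears on this exchange, since the only other compound carrying a sulfanyl group ends at a limit. A step of no size beyond the usual scatter is therefore expected in this assay, and compound 3 is expected to stand near 70000 nM, between 30000 nM and 150000 nM. The step of a 1.0-fold lower number from compound 2 to compound 3 (0.00 log units; within the scatter) that this estimate means is expected to be small.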

Compound 3, concentration lethal to 50% of the cells: 75900 nM
Compound 3: middle estimate off by 1.1-fold (0.04 log units), on the low side; low and high end bracket the measured number.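

In this assay, going by these compounds alone, the exchange at this aromatic carbon, next to the ring nitrogen and ortho to a phenyl group, gives the first step of readable size: a 1.1-fold higher number from compound 2 to compound 3 (0.03 log units; within the scatter). With the 4-fluorophenyl ring kept in place, the oxygen link and the sulfur link therefore cannot be told apart at this position in this read-out. The steps from compound 1 cannot be read, since that compound ends at a limit and not at a number: the limit of < 100000 nM in this assay, at which 1 of the 3 values shown sits.

The compounds shown leave open whether an amine, a carboxylic acid or a longer chain at this carbon would move the number beyond the scatter. Also open, going by these compounds, is what fluoro in place of methoxy does on the ring attached through sulfur.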